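The source may report more compounds than this note shows. Statements on the series, on what has been measured and on what is new or still open speak of the compounds shown alone.

Measured in a functional assay on HL-60 cells (Homo sapiens) for cytotoxicity, read by luminescence and CellTiter-Glo, with a stated time of 3 days; a lower number here means a stronger inhibitor, a higher number a weaker inhibitor:
Compound 1 `N#Cc1ccc(NC(=O)c2cc(-c3ccncc3)ccc2O)cc1`: 5410 nM
Compound 2 `N#Cc1ccc(NC(=O)c2ccc(Cl)cc2O)cc1`: 1300 nM

Compound 1 has the higher of these two numbers, and its gap to compound 2 lies beyond the scatter of repeat measurements. The unmeasured compound 3 `N#Cc1ccc(NC(=O)c2cc(F)ccc2O)cc1` has fluoro in place of pyridin-4-yl on an aromatic carbon. Within the data shown here, no measured pair shows this single change, so any forecast is uncertain. Compound 2, which also lacks pyridin-4-yl, gives 1300 nM, so a moderate fall in the this assay number is expected. The expected change is a 2.2-fold lower number from compound 1 to compound 3 (0.34 log units; beyond the scatter). For compound 3 the estimated value is 2500 nM, within an expected range of 800 nM to 7500 nM.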

Compound 3, half-maximal inhibitory concentration: 1420 nM
Compound 3: the middle estimate sits 1.8-fold (0.25 log units) above what was measured; the measured number falls inside the stated range.
By their numbers in this assay, from the lowest: compounds 2 and 3 (each within the scatter of the next); then compound 1.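

At this carbon, para to a hydroxy group, putting fluoro in place of pyridin-4-yl gives a 3.8-fold lower number from compound 1 to compound 3 (0.58 log units; beyond the scatter) in this assay. The ring is therefore not needed here for activity in this assay, and a single fluorine atom does better than the six-membered aromatic ring. Nothing measured here explains why the smaller group gives the lower number. As far as these compounds go, it remains open whether the step comes from losing pyridin-4-yl or from adding fluoro. Plain hydrogen, a methoxy group or an amine at this carbon would help separate the two.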